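The source may report more compounds than this note shows. Statements on the series, on what has been measured and on what is new or still open speak of the compounds shown alone.

Four compounds share a common framework and differ only in small attachments. Compound 1 `Cc1ccc2[nH]c(C(=O)N[C@H]3CN(S(=O)(=O)c4ccccc4)C[C@@H]3C(=O)N[C@H]3CCCN(C)C3)cc2c1` and compound 3 `Cc1ccc2[nH]c(C(=O)N[C@H]3CCN(S(=O)(=O)c4ccccc4Cl)C[C@@H]3C(=O)N[C@H]3CCCN(C)C3)cc2c1` each carry a methyl group on a ring nitrogen; compound 2 `Cc1ccc2[nH]c(C(=O)N[C@H]3CN(S(=O)(=O)c4ccccc4)C[C@@H]3C(=O)N[C@H]3CCCNC3)cc2c1` and compound 4 `Cc1ccc2[nH]c(C(=O)N[C@H]3CCN(S(=O)(=O)c4ccccc4Cl)C[C@@H]3C(=O)N[C@H]3CCCNC3)cc2c1` carry a hydrogen there instead. How the core of compound 1 and the core of compound 3 differ is not broken down here.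

The three measured compounds were tested in an ADME assay on cells (Hepatocyte, Rattus norvegicus) for metabolic stability; a higher number here means faster removal of the compound, a lower number slower removal. Compound 1 gives 23 uL/min, compound 2 gives 7 uL/min and compound 3 gives 66 uL/min, the highest of the three.

The change from compound 1 to compound 2, (hydrogen in place of methyl on an amine nitrogen in a ring), produced a 3.3-fold lower number from compound 1 to compound 2 (0.52 log units; beyond the scatter). The change from compound 3 to compound 4 is hydrogen in place of methyl on an amine nitrogen in a ring, the same change at the same place, set on the core of compound 3 rather than that of compound 1.

Compound 4 has not yet been measured in this assay. Because compound 1 went to compound 2 with a 3.3-fold lower number from compound 1 to compound 2 (0.52 log units; beyond the scatter), a step of similar size is expected from compound 3 to compound 4, namely a 3.3-fold lower number from compound 3 to compound 4 (0.52 log units; beyond the scatter). On that basis compound 4 is estimated at 20 uL/min, with a range from 10 uL/min to 40 uL/min allowing for the usual scatter and for the fact that the two cores are not the same. Going by the values given here, only one prior example of this change exists here, so the expectation rests on a single step.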

Compound 4, intrinsic clearance in a liver preparation (reported as CLH), per the amount of preparation that the assay uses: 7 uL/min
Compound 4: the middle estimate sits 2.9-fold (0.46 log units) above what was measured; measured number outside the range, below it.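

Putting hydrogen in place of methyl on the amine nitrogen of the six-membered ring gave a 9.4-fold lower number from compound 3 to compound 4 (0.97 log units; beyond the scatter) in this assay, so removal of the compound is slower without the methyl on this core too. Across the two cores, the direction of the change carried over but its size did not, and the step on the core of compound 3 is the larger one: the same change on two cores in this assay, a 3.3-fold lower number (0.52 log units; beyond the scatter) from compound 1 to compound 2 and a 9.4-fold lower number (0.97 log units; beyond the scatter) from compound 3 to compound 4, 2.9-fold (0.46 log units) apart, beyond the scatter of two such steps. This shows that, in these four compounds, the direction of this change held from one core to the other, while the size of the step on one core was a poor guide to its size on the other; it does not show why the steps differ, which of the differences between the cores matters, or whether the same direction would hold on any further core in the series.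

The two cores differ in more than one way, so a compound carrying only one of those differences would be needed to tell which of them goes with the larger step. Going by these compounds, it also remains open where the number would fall with a different group on the same ring nitrogen, such as an ethyl group or an acetyl group, in place of the methyl or the hydrogen.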